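Nitro to amino in a fluorinated sulfonamide series

The source may hold more compounds than are shown below. What is called first, only, known or untested is meant among the compounds shown, and "the series" means these compounds.

Measured so far in a functional assay on DU-145 cells (Homo sapiens) for cytotoxicity, read by trypan blue exclusion, with a stated time of 96 h; a higher number here means a weaker inhibitor, a lower number a stronger inhibitor
- compound 1 `COc1cc(OC)c(/C=C/S(=O)(=O)Nc2ccc(F)c(N)c2)c(OC)c1` gives 10000 nM
- compound 2 `COc1ccc(NS(=O)(=O)/C=C/c2c(F)c(F)c(F)c(F)c2F)cc1F` gives 10000 nM
- compound 3 `COc1ccc(/C=C/S(=O)(=O)Nc2c(F)c(F)c(F)c(F)c2F)cc1[N+](=O)[O-]` gives 100000 nM

Compound 3 holds the highest of the three numbers, and its distance to each of the other two lies beyond the scatter. Compound 1 and compound 2 share the same value. Among these three, only compound 3 carries a nitro group.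

Compound 4 `COc1ccc(/C=C/S(=O)(=O)Nc2c(F)c(F)c(F)c(F)c2F)cc1N` is the unmeasured partner of compound 3, with amino in place of nitro on an aromatic carbon, ortho to a methoxy group amino in place of nitro on an aromatic carbon and with the rest of the structure unchanged.

Going by the values given here, no two measured compounds differ in one place, so the series gives no direct measure of this change. The evidence is indirect and thin. Compound 1 carries an amino group and gives 10000 nM in this assay while compound 2 has none and gives 10000 nM so the amino group alone marks no difference between those two. Compound 3 at 100000 nM still leaves room for a lower number.

A step toward a lower number, beyond the scatter, is expected (a 17-fold lower number from compound 3 to compound 4 (1.22 log units; beyond the scatter)) though with wide uncertainty. Estimated for compound 4 is 6000 nM within an expected range from 600 nM to 50000 nM until a measurement is available.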

Compound 4, half-maximal inhibitory concentration: 35000 nM
Beside the measured number, compound 4's estimate is 5.8-fold (0.77 log units) below it; measured number inside the range.
By their numbers in this assay, from the lowest: compounds 1 and 2 (each within the scatter of the next); then compound 4; then compound 3.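

In this assay the change from nitro to amino, on an aromatic carbon ortho to a methoxy group, now has a direct reading of a 2.9-fold lower number from compound 3 to compound 4 (0.46 log units; beyond the scatter) and that step, though modest, lies beyond the scatter. Going by these compounds alone, this matched pair, which the earlier compounds could not provide, shows that the number responds to the group at this position while the rest of the structure stays fixed, and the amino partner lies on the lower side. No measurement at hand explains the step, and the pair cannot separate the departure of nitro from the arrival of amino.

Going by these compounds, whether other groups at this position, such as a hydroxyl, an acetamide or a dimethylamino group, would move the number further in either direction remains open, as does the effect of removing the methoxy group that sits ortho to it. With only one nitro and amino pair among the compounds shown, it is also open whether this change would give a step of similar size on a different core, such as that of compound 1 or compound 2.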